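A few compounds are considered here, and "the series" means these few. Any claim that something is new, unique, unknown or untested is made for them only; others in the source may bear on it.

Compound 1 `CC(C)(C)C(=O)Nc1ncc(C(Oc2ccc3cc(Br)ccc3c2)c2ccc(Cl)cc2)s1` was tested in an ADME assay on HepG2 2.2.15 cells (Homo sapiens) for cytotoxicity (a lower number here means that less compound is tolerated, a higher number that more compound is tolerated), where compound 1 is recorded as "not toxic" (no number reported) without any number. Compound 2 `COc1ccc(C(=O)Nc2ncc(C(Oc3ccc4cc(Br)ccc4c3)c3ccc(Cl)cc3)s2)cc1` carries a (4-methoxyphenyl)carbonyl group on the amide-type nitrogen of the shared core. In this assay compound 2 gives > 50000 nM, which is a limit of the assay rather than a measured number. This is the limit of > 50000 nM in this assay, at which 1 of the 2 values shown sits, so neither value gives a fixed point to measure a step from. Compound 3 `O=C(Nc1ncc(C(Oc2ccc3cc(Br)ccc3c2)c2ccc(Cl)cc2)s1)c1ccc(F)cc1Br` differs from compound 2 by 2-bromo-4-fluorophenyl in place of 4-methoxyphenyl on a carbonyl carbon. For the measured compounds named here, no step between measured compounds is available, so the direction can only be judged loosely. The step from compound 2 to compound 3 in this assay is expected to be an at least 1.4-fold lower number from compound 2 to compound 3 (0.15 log units; that floor lies within the scatter), a shift toward slightly less tolerance that may well stay within the scatter. Compound 3 is therefore expected to give about 35000 nM in this assay, between 12000 nM and 100000 nM.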

Compound 3, half-maximal cytotoxic concentration: > 50000 nM
Compound 3: only a limit was reported (the forecaster's own chance of this, stated with the estimate: 45%); middle value at least 1.4-fold (0.15 log units) away from the limit.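

Compound 2 and compound 3 both sit at a limit rather than at a number, so no step between them can be read in this assay: the limit of > 50000 nM in this assay, at which 2 of the 3 values shown sit.

The compounds shown leave open whether 2-bromo-4-fluorophenyl in place of 4-methoxyphenyl on a carbonyl carbon shifts the tolerated concentration at all.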